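Ether to Benzylic Alcohol on a Sulfonamide Core

The compounds below may be only part of what the source reports. "The series", "measured", "known", "first", "only" and "open" are said of these compounds alone.

Measured compounds:
Compound 1 `C[C@@H](c1ccc(Cl)cc1)N1Cc2cncn2C(CC2(C)COC2)S1(=O)=O` gives 340 nM in an assay on cells for inhibition of cytochrome P450 11B1, mitochondrial (Homo sapiens); on this read-out higher numbers stand for weaker inhibition and lower numbers for stronger inhibition.
Compound 2 `CC(C)OCC1n2cncc2CN([C@@H](C)c2ccc(Cl)cc2)S1(=O)=O` gives 222 nM in this assay.

Compound 2 and compound 1 sit within the scatter of each other: the step of a 1.5-fold lower number from compound 1 to compound 2 (0.19 log units; within the scatter) counts as no real change. Compound 3 `C[C@@H](c1ccc(Cl)cc1)N1Cc2cncn2C(C[C@H](O)c2ccccc2)S1(=O)=O` differs from compound 2 by hydroxy(phenyl)methyl in place of isopropoxy on a saturated chain carbon bound to a saturated ring carbon. Within the data shown here, only that one step touches the same place, and it was small, while the new group brings an aromatic ring and a hydrogen-bond donor that no measured compound here carries, so the expectation is loose. For compound 3 the expected step is a 1.1-fold higher number from compound 2 to compound 3 (0.05 log units; within the scatter), and the estimate is 250 nM, with a range from 60 nM to 1000 nM.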

Compound 3, half-maximal inhibitory concentration: 182 nM
Estimate against measurement, compound 3: 1.4-fold (0.14 log units) above; the range from low to high includes it.
By their numbers in this assay, from the lowest: compounds 3, 2 and 1 (each within the scatter of the next).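

Swapping isopropoxy for the larger hydroxy(phenyl)methyl, which adds an aromatic ring and a hydrogen-bond donor, gives a 1.2-fold lower number from compound 2 to compound 3 (0.09 log units; within the scatter) in this assay and so no real change. Measured against the 3-methyloxetan-3-yl group, the same new group gives a 1.9-fold lower number from compound 1 to compound 3 (0.27 log units; within the scatter) and again stays within the scatter, so all three groups at this place read alike. Nothing measured here explains this result.

On these data alone, the separate contributions of the hydroxy and the phenyl ring remain open. So does whether an amine or a carboxylic acid at this place would move the number beyond the scatter.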